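Methylselanyl to methylsulfanyl swap on the quinazoline-type core

A few compounds are considered here, and "the series" means these few. Any claim that something is new, unique, unknown or untested is made for them only; others in the source may bear on it.

Measured so far:
compound 1 `Sc1nc(NCc2ccccc2)c2ccccc2n1`: > 100000 nM
compound 2 `CSc1nc(NCc2ccc([Se]C)cc2)c2ccccc2n1`: > 100000 nM
compound 3 `C[Se]c1nc(NCc2ccccc2)c2ccccc2n1`: 83500 nM

Among the measured compounds shown here, in a functional assay on CCRF-CEM cells (Homo sapiens) for cytotoxicity, read by MTT assay, with a stated time of 72 h (on this read-out higher numbers stand for lower toxicity in this test and lower numbers for higher toxicity in this test), compound 3 gives 83500 nM and is the only compound of the three with a numerical result. For compound 1 the result is a limit of the test, > 100000 nM. For compound 2 the result is likewise a limit, > 100000 nM. Both sit at the limit of > 100000 nM in this assay, at which 2 of the 3 values shown sit.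

For the measured compounds named here, the one measured step that bears on the series, an at least 1.1-fold lower number from compound 1 to compound 3 (0.07 log units; that floor lies within the scatter), is a floor that lies within the scatter, so it gives no direction for further changes at this aromatic carbon.

Compound 4 `CSc1nc(NCc2ccccc2)c2ccccc2n1` is not yet measured. Its difference from compound 3 is a group of 2 heavy atoms (1 carbon, 1 sulfur; no ring) in place of a group of 2 heavy atoms (1 carbon, 1 selenium; no ring), on an aromatic carbon. Going by the values given here, no measured pair isolates this exchange; compound 2 carries the methylsulfanyl group in the same place and gives only a limit, but it differs from compound 4 in a second place as well, so no step can be drawn from it.

With only a within-scatter step available, no change beyond the scatter is expected for this assay. Compound 4 is expected to give 100000 nM, with a range from 40000 nM to 300000 nM, and the expected step is a 1.2-fold higher number from compound 3 to compound 4 (0.08 log units; within the scatter); a limit rather than a number is a real possibility.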

Compound 4, concentration lethal to 50% of the cells: > 100000 nM
Compound 4: only a limit was reported (the forecaster's own chance of this, stated with the estimate: 60%); the middle value lies on the limit itself.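

In this assay, among the compounds shown here, compound 3 and compound 4 form the first pair that isolates the exchange of the selenium-bearing group for methylsulfanyl on this aromatic carbon between two ring nitrogen atoms. This pair gives an at least 1.1-fold higher number from compound 3 to compound 4 (0.07 log units; that floor lies within the scatter), so no difference between the two groups can be told from the scatter at this position, and the exchange gives no direction for further changes here. The steps from compound 2 to compound 4 and from compound 1 to compound 4 cannot be read, and the series stays concentrated at one end of the test range: the limit of > 100000 nM in this assay, at which 3 of the 4 values shown sit.

Going by these compounds, it remains open whether any group on this aromatic carbon can give a number clearly apart from the scatter in this assay, for example an amine or a longer alkyl chain in place of methylsulfanyl. For the compounds shown here, it also remains open whether a change at another place on the molecule, such as a carboxylic acid, would alter the read-out when made as the only difference from compound 3 or compound 4.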